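Replacing Hydroxy on a Sulfonyl Sulfur with Pyridinylamino

A few compounds are considered here, and "the series" means these few. Any claim that something is new, unique, unknown or untested is made for them only; others in the source may bear on it.

Three compounds have been measured in an assay on HEK293 cells for inhibition of solute carrier family 22 member 12 (Homo sapiens); a higher number here means a weaker inhibitor, a lower number a stronger inhibitor:

compound 1, `NS(=O)(=O)CSc1nnc(Br)n1Cc1ccc(Br)c2ccccc12`, giving 365000 nM
compound 2, `O=S(=O)(O)CSc1nnc(Br)n1Cc1ccc(Br)c2ccccc12`, giving 14400 nM
compound 3, `O=S(=O)(CSc1nnc(Br)n1Cc1ccc(Br)c2ccccc12)Nc1cccnc1Br`, giving 280 nM

Compound 2 stands second highest of the three numbers. Its nearest neighbour is compound 1, with a 25-fold lower number from compound 1 to compound 2 (1.40 log units; beyond the scatter); its furthest is compound 3, with a 51-fold lower number from compound 2 to compound 3 (1.71 log units; beyond the scatter). The remaining pair shows a 1300-fold lower number from compound 1 to compound 3 (3.12 log units; beyond the scatter).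

The compound now in question is compound 4, `COc1ncccc1NS(=O)(=O)CSc1nnc(Br)n1Cc1ccc(Br)c2ccccc12`. It differs from compound 2 in one place: (2-methoxypyridin-3-yl)amino in place of hydroxy on a sulfonyl sulfur.

Within the data shown here, the step that bears most directly on this change is the one from compound 2 to compound 3, where a (2-bromopyridin-3-yl)amino took the place of hydroxy on the same sulfonyl sulfur and the number fell by a 51-fold lower number from compound 2 to compound 3 (1.71 log units; beyond the scatter). Compound 4 carries a (2-methoxypyridin-3-yl)amino at that position instead, so the change is of the same kind, with a methoxy where compound 3 has a bromine on the pyridine ring. Among the measured compounds shown here, no measured pair separates those two groups, so their difference cannot be read from the data. Compound 4 is therefore expected to show a large drop in this assay of about a 36-fold lower number from compound 2 to compound 4 (1.56 log units; beyond the scatter), landing near compound 3. The estimate for compound 4 is 400 nM, with a range from 100 nM to 2000 nM.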

Compound 4, half-maximal inhibitory concentration: 4050 nM
For compound 4 the middle estimate is 10-fold (1.01 log units) below the measured one; measured number above the stated range.
By their numbers in this assay, from the lowest: compound 3; then compound 4; then compound 2; then compound 1.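

In this assay, the group carried on the pyridine ring turns out to matter a great deal at this position: methoxy in place of bromo on an aromatic carbon gives a 14-fold higher number from compound 3 to compound 4 (1.16 log units; beyond the scatter) and so shows that the two pyridinylamino groups are not interchangeable on the sulfonyl sulfur. Replacing hydroxy with (2-methoxypyridin-3-yl)amino yields only a modest gain, a 3.6-fold lower number from compound 2 to compound 4 (0.55 log units; beyond the scatter), whereas the step from the unsubstituted sulfonamide stays large at a 90-fold lower number from compound 1 to compound 4 (1.95 log units; beyond the scatter), so a pyridine ring on the sulfonamide nitrogen lowers the number in both compound 3 and compound 4, though by clearly different amounts. Nothing available here accounts for the difference between the bromo and methoxy groups.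

From the compounds shown here alone, whether a chloro, methyl or amino group on the pyridine ring would bring the number closer to that of compound 3 or of compound 4 remains open. Also open, going by these compounds, is what the ring nitrogen itself contributes, a question that a plain phenyl ring on the sulfonamide nitrogen could address.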